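This account rests on a few compounds, and the source may have more. Where it says the series, first, only, none or still open, it means among the compounds named here.

Compound 1 `CC(C)=CC[C@@H](OC(=O)CCO)C1=CC(=O)c2c(O)ccc(O)c2C1=O`: 55300 nM
Compound 2 `CC(C)=CC[C@@H](OC[C@H](C)O)C1=CC(=O)c2c(O)ccc(O)c2C1=O`: 24500 nM
Compound 3 `CC(C)=CC[C@@H](OC[C@@H](C)O)C1=CC(=O)c2c(O)ccc(O)c2C1=O`: 14300 nM

All three compounds were tested in a functional assay on DU-145 cells (Homo sapiens) for cytotoxicity, read by MTT assay; a higher number here means a weaker inhibitor, a lower number a stronger inhibitor. There, compound 3 gives 14300 nM. It stands level with its partner within the scatter, at a 1.7-fold lower number from compound 2 to compound 3 (0.23 log units; within the scatter), and clearly apart from the remaining compound, at a 3.9-fold lower number from compound 1 to compound 3 (0.59 log units; beyond the scatter).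

The next compound, compound 4 `CC(=O)OCCO[C@H](CC=C(C)C)C1=CC(=O)c2c(O)ccc(O)c2C1=O`, carries acetoxymethyl in place of 1-hydroxyethyl on a saturated chain carbon bound to an oxygen on a saturated carbon. Cut one bond further out, this reads as 2-hydroxypropyl to 2-acetoxyethyl.

Within the data shown here, no measured step makes this exact exchange. The nearest guides are the other side-chain changes, a 2.3-fold lower number from compound 1 to compound 2 (0.35 log units; beyond the scatter) and a 3.9-fold lower number from compound 1 to compound 3 (0.59 log units; beyond the scatter), both modest, together with the configuration step a 1.7-fold lower number from compound 2 to compound 3 (0.23 log units; within the scatter). With only these modest steps as a guide, no shift beyond the scatter is expected in this assay, and no direction can be favoured, although a modest move either way remains possible. The expected change is a 1.0-fold higher number from compound 3 to compound 4 (0.02 log units; within the scatter). For compound 4 the estimated value is 15000 nM, with an expected range of 5000 nM to 45000 nM.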

Compound 4, half-maximal inhibitory concentration: 15500 nM
For compound 4 the middle estimate is 1.0-fold (0.01 log units) below the measured one; low and high end bracket the measured number.
By their numbers in this assay, from the lowest: compounds 3, 4 and 2 (each within the scatter of the next); then compound 1.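

In this assay, acetoxymethyl in place of 1-hydroxyethyl on a saturated chain carbon bound to an oxygen on a saturated carbon removes the hydrogen-bond donor and the defined stereocentre of that group, yet the number stays within the scatter of both earlier partners (a 1.1-fold higher number from compound 3 to compound 4 (0.03 log units; within the scatter)) and (a 1.6-fold lower number from compound 2 to compound 4 (0.20 log units; within the scatter)). The side chain therefore tolerates this larger group without a free hydroxyl or a chain stereocentre, which matches the earlier configuration pair, a comparison that is clean for one reason: (the fact that compounds 2 and 3 differ only in the configuration as drawn). Only compound 1, with its (2-hydroxyethyl)carbonyl group, stands apart from this set (a 3.6-fold lower number from compound 1 to compound 4 (0.55 log units; beyond the scatter)).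

Going by these compounds, whether an amine, a carboxylic acid or a longer chain at this place would also stay level remains open. The compounds shown also leave open what sets compound 1 apart.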